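Cytotoxicity notes: compound 3 to compound 4

The compounds below may be only part of what the source reports. "The series", "measured", "known", "first", "only" and "open" are said of these compounds alone.

Measured so far:
compound 1 `CCC1(c2ccccc2OC)CC(S(=O)(=O)c2ccc(F)cc2)=C(c2ccc(/C(N)=N\O)cc2)O1` gives 27000 nM
compound 2 `CC1(Cc2ccccc2)CC(S(=O)(=O)c2ccccc2F)=C(c2ccc(/C(N)=N\O)cc2)O1` gives 61700 nM
compound 3 `CC1(c2ccc(Br)cc2)CC(S(=O)(=O)c2ccc(F)cc2)=C(c2ccc(/C(N)=N\O)cc2)O1` gives 19200 nM

All three values come from an ADME assay on HepG2 cells (Homo sapiens) for cytotoxicity, read by MTT assay, with a stated time of 72 h; a lower number here means that less compound is tolerated, a higher number that more compound is tolerated. Compound 3 carries the lowest of the three numbers; the gap to compound 1 lies within the usual scatter of repeats, so the two cannot be ordered, whereas the gap to compound 2 lies beyond it, and compound 2 is tolerated at a clearly higher concentration than compound 3.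

Compound 4 `CC1(c2ccc(Cl)cc2)CC(S(=O)(=O)c2ccc(F)cc2)=C(c2ccc(/C(N)=N\O)cc2)O1` is the next compound in the series and has not yet been measured in this assay. Against compound 3 the change is chloro in place of bromo on an aromatic carbon. Within the data shown here, nothing in the measured set isolates a bromo to chloro exchange, so no measured step of this kind is available to lean on.

With only the value of compound 3 as anchor, the expectation for compound 4 is a step of about a 1.1-fold higher number from compound 3 to compound 4 (0.06 log units; within the scatter) in this assay, which is to say no step beyond the scatter in either direction. The estimate for compound 4 in this assay is therefore 22000 nM, with a range from 11000 nM to 45000 nM.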

Compound 4, half-maximal cytotoxic concentration: 61400 nM
Beside the measured number, compound 4's estimate is 2.8-fold (0.45 log units) below it; the whole stated range lies below it.
By their numbers in this assay, from the lowest: compounds 3 and 1 (each within the scatter of the next); then compounds 4 and 2 (each within the scatter of the next).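

In this assay, chloro in place of bromo on an aromatic carbon gives a 3.2-fold higher number from compound 3 to compound 4 (0.50 log units; beyond the scatter), the only step among the compounds shown that isolates a single place. The exchange of 4-bromophenyl to 4-chlorophenyl swaps one heavy atom for one heavy atom, with no ring, no hydrogen-bond donor or acceptor and no net charge on either side, and that alone moves the number beyond the scatter, towards more compound tolerated; compound 1 and compound 2 differ from compound 3 in more than one place and could not show this. Nothing measured here bears on why this exchange produces a step of this size.

Going by these compounds, this remains a single pair, so it is open whether the same exchange would give a similar step on a core carrying the other groups of compound 1 or compound 2. Also open, on these data alone, is where an amine, a nitrile or a plain hydrogen at this same place on the ring would fall relative to compound 3 and compound 4 in this assay.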